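The compounds below may be only part of what the source reports. "The series", "measured", "known", "first", "only" and "open" are said of these compounds alone.

Compound 1 `COc1cc(N(CC2CC2)c2cccc(C(F)(F)F)c2)cnc1C(=O)[C@H]1C[C@@H]1C(=O)O` gives 52.4 nM in an assay on isolated protein for inhibition of leukotriene C4 synthase (Homo sapiens), read by LC-MS, with stated times of 45 min and 20 min; a lower number here means a stronger inhibitor, a higher number a weaker inhibitor. Compound 2 `COc1cc(N(CC(C)C)c2cccc(C(F)(F)F)c2)cnc1C(=O)[C@H]1C[C@@H]1C(=O)O` gives 20.6 nM. Compound 3 `CCCN(c1cccc(C(F)(F)F)c1)c1cnc(C(=O)[C@H]2C[C@@H]2C(=O)O)c(OC)c1` gives 58.4 nM.

Among these three numbers compound 1 stands second highest; its nearest neighbour is compound 3, at a 1.1-fold higher number from compound 1 to compound 3 (0.05 log units; within the scatter), and its furthest is compound 2, at a 2.5-fold lower number from compound 1 to compound 2 (0.41 log units; beyond the scatter). The step to compound 2 is the only one beyond the scatter, as is a 2.8-fold higher number from compound 2 to compound 3 (0.45 log units; beyond the scatter).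

Compound 4 `COc1cc(N(CC2CC2)c2cc(C(F)(F)F)ccc2F)cnc1C(=O)[C@H]1C[C@@H]1C(=O)O` differs from compound 1 by fluoro in place of hydrogen on an aromatic carbon. All three measured steps concern the saturated chain on the nitrogen; none touches the aromatic ring that carries the trifluoromethyl group, so none bears directly on this change. For the measured compounds named here, with no precedent, compound 4 is expected to stay close to compound 1, a step of a 1.2-fold lower number from compound 1 to compound 4 (0.07 log units; within the scatter) in this assay. The estimate for compound 4 is 45 nM, ranging from 15 nM to 150 nM.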

Compound 4, half-maximal inhibitory concentration: 14 nM
Beside the measured number, compound 4's estimate is 3.2-fold (0.51 log units) above it; the whole stated range lies above it.
By their numbers in this assay, from the lowest: compounds 4 and 2 (each within the scatter of the next); then compounds 1 and 3 (each within the scatter of the next).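

In this assay, fluoro in place of hydrogen on an aromatic carbon, ortho to a large group and para to a trifluoromethyl group, gives a 3.7-fold lower number from compound 1 to compound 4 (0.57 log units; beyond the scatter) and so shows that this position responds to a change of a single atom. It is the first step shown on this ring, and it is beyond the scatter, while the earlier steps all concern the saturated chain on the nitrogen. Nothing given here accounts for this step. As far as these compounds go, whether chloro, methyl or an amine at this position would act as fluoro does remains open. So does whether fluoro would give a similar step with the chain of compound 2 or compound 3.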